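Trimming the Outer Ring of a Cinnamamide Tail

The compounds below may be only part of what the source reports. "The series", "measured", "known", "first", "only" and "open" are said of these compounds alone.

Of the compounds shown here, two have so far been tested in a functional assay on HT-29 cells (Homo sapiens) for cytotoxicity, read by MTT assay, with a stated time of 72 h; a higher number here means a weaker inhibitor, a lower number a stronger inhibitor. Compound 1 `COc1ccc(C(=O)c2cc(OC)c(OC)c(OC)c2)cc1N` carries a free amine on the shared core and gives 50 nM. Compound 2 `C#CCOc1cccc(/C=C/C(=O)Nc2cc(C(=O)c3cc(OC)c(OC)c(OC)c3)ccc2OC)c1` has that amine capped as a cinnamamide whose outer ring is a 3-(propargyloxy)phenyl group; in this assay compound 2 gives 7400 nM. Of the two numbers, compound 2 stands at the higher one, and its distance from compound 1 lies well beyond the scatter of repeated measurements.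

Compound 3 `COc1ccc(C(=O)c2cc(OC)c(OC)c(OC)c2)cc1NC(=O)/C=C/c1ccc(F)cc1` keeps the cinnamamide and alters only its outer ring: 4-fluorophenyl in place of 3-(propargyloxy)phenyl on a double-bonded chain carbon bound to a double-bonded chain carbon. For the measured compounds named here, no measured pair differs in exactly this way, so the size of this step cannot be read from data and rests on expectation alone. Both compound 2 and compound 3 retain the capped amine, so a number much nearer compound 2 than compound 1 seems likely, with a small move toward lower values expected, a 1.9-fold lower number from compound 2 to compound 3 (0.27 log units; within the scatter). Compound 3 is therefore estimated at 4000 nM, with a plausible range from 800 nM to 20000 nM.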

Compound 3, half-maximal inhibitory concentration: 1800 nM
Compound 3: middle estimate off by 2.2-fold (0.35 log units), on the high side, within the range that was stated.
By their numbers in this assay, from the lowest: compound 1; then compound 3; then compound 2.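

In this assay, the outer ring of the cinnamamide proves to be a place where the number responds: 4-fluorophenyl in place of 3-(propargyloxy)phenyl gives a 4.1-fold lower number from compound 2 to compound 3 (0.61 log units; beyond the scatter). Even so, the cinnamamide with this lower number remains far from the free amine, with a 36-fold higher number from compound 1 to compound 3 (1.56 log units; beyond the scatter), a single change in one place that shows the size of capping the nitrogen with this tail. The swap removes the propargyloxy group and adds a fluorine in one step, so the two parts of the change cannot be told apart, and no measurement here accounts for the size of either step.

A plain phenyl ring at the same place would show how much of the step remains without any fluorine, while a 3-fluorophenyl ring would test the same atom under the numbering of the group it replaced. An acetyl group on the nitrogen would be a smaller amide to measure. Its number would show whether a higher number than that of the free amine is also seen without the full cinnamamide chain and its outer ring.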